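The source may report more compounds than this note shows. Statements on the series, on what has been measured and on what is new or still open speak of the compounds shown alone.

Measured so far in a functional assay on KB cells (Homo sapiens) for antiproliferative activity, read by MTT assay, with a stated time of 72 h; a higher number here means a weaker inhibitor, a lower number a stronger inhibitor
Compound 1 `COc1ccc(-c2ccsc2-c2cc(OC)c(OC)c(OC)c2)cc1` gives 7400 nM
Compound 2 `COc1ccc(-c2ccsc2-c2cc(OC)c(OC)c(OC)c2)cc1OCc1ccccc1` gives > 100000 nM as a limit of the assay

Among the compounds with values here, compound 2 stands at a limit, with the limit of > 100000 nM in this assay, at which 1 of the 2 values shown sits, as the only reading of it. Compound 3 `COc1ccc(-c2ccsc2-c2cc(OC)c(OC)c(OC)c2)cc1O` follows from compound 2 by hydrogen in place of benzyl on an oxygen on an aromatic ring in which benzyloxy goes to hydroxy. Within the data shown here, the one measured step bearing on this is an at least 13-fold higher number from compound 1 to compound 2 (1.13 log units; beyond the scatter) and it is large and beyond the scatter, with benzyloxy in place of hydrogen on an aromatic carbon. Losing the benzyl is therefore expected to bring a large step to a lower number in this assay and the estimated step is an at least 33-fold lower number from compound 2 to compound 3 (1.52 log units; beyond the scatter) in that direction. For compound 3 the estimated value is 3000 nM with an expected range from 400 nM to 20000 nM in this reading.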

Compound 3, half-maximal inhibitory concentration: 1530 nM
Estimate against measurement, compound 3: 2.0-fold (0.29 log units) above; the measured number falls inside the stated range.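

Swapping the hydrogen for a hydroxy gives a 4.8-fold lower number from compound 1 to compound 3 (0.68 log units; beyond the scatter), so a group at this place can lower the number, which the earlier compounds did not show. Hydrogen in place of benzyl gives an at least 65-fold lower number from compound 2 to compound 3 (1.81 log units; beyond the scatter), so the loss seen with benzyloxy goes with the benzyl and not with the oxygen alone. Compound 2 stands at a limit, so this step has no measured upper end: the limit of > 100000 nM in this assay, at which 1 of the 3 values shown sits.

The compounds shown leave open how an amine at this place would read. They also leave open where an ethoxy or a longer alkoxy chain would fall between hydroxy and benzyloxy.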